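Adding a Methyl to an Amide with a Lower Inhibition Number

The compounds below may be only part of what the source reports. "The series", "measured", "known", "first", "only" and "open" are said of these compounds alone.

Compound 2 `CCNC(=O)C1=C(C)NC(=O)NC1c1cccs1` stands lowest of the two numbers measured in an assay on membranes from CHO cells for displacement of a labelled ligand from adenosine receptor A1 (Homo sapiens), read by scintillation counting, with a stated time of 60 min, tested at 1 uM; a lower number here means less inhibition, a higher number more inhibition at the concentration tested (going by the name of the read-out); compound 2 gives 1%, while compound 1 `CC1=C(C(=O)CC(C)C)C(c2cccs2)NC(=O)N1` gives 19%. Among the measured compounds shown here, the only measured step, a number 18 percentage points lower from compound 1 to compound 2 (beyond the scatter), came from placing ethylamino in place of isobutyl on a carbonyl carbon. Compound 3 `CC1=C(C(=O)NC(C)C)C(c2cccs2)NC(=O)N1` differs from compound 2 by methyl in place of hydrogen on a saturated chain carbon bound to an amide-type nitrogen and a saturated chain carbon. The expected step of a number 4 percentage points higher from compound 2 to compound 3 (within the scatter) is small and within the scatter, because a number 18 percentage points lower from compound 1 to compound 2 (beyond the scatter) was only modest although that swap altered much more than methyl in place of hydrogen. Compound 3 is therefore estimated at 5%, between -5% and 15%.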

Compound 3, a percentage reported as inhibition, at one concentration (the size of the read-out at that concentration, not a potency): 2%
Beside the measured number, compound 3's estimate is 3 percentage points above it; the measured number falls inside the stated range.
By their numbers in this assay, from the lowest: compounds 2 and 3 (each within the scatter of the next); then compound 1.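

In this assay, extending ethylamino to isopropylamino gives a number 1 percentage points higher from compound 2 to compound 3 (within the scatter), so this added methyl does not separate the two amides. With isopropylamino in place of isobutyl on the carbonyl carbon, the result is a number 17 percentage points lower from compound 1 to compound 3 (beyond the scatter), so a second amide also differs from compound 1 in the same direction. Nothing available explains either step.

Going by these compounds, it remains open whether a longer chain such as n-butylamino, or a ring-bearing group such as benzylamino, would stay at this level. On these data alone, a free carboxylic acid at the same carbonyl carbon is equally open.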